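The source may hold more compounds than are shown below. What is called first, only, known or untested is meant among the compounds shown, and "the series" means these compounds.

Measured in a functional assay on HCT-15 cells (Homo sapiens) for cytotoxicity, read by MTT assay, with a stated time of 2 days; a higher number here means a weaker inhibitor, a lower number a stronger inhibitor:
Compound 1 `Cc1ccc2nc(-c3ccccc3C(F)(F)F)[nH]c(=O)c2c1`: > 50000 nM, a limit of the assay
Compound 2 `Cc1ccc2c(=O)[nH]c(-c3ccccc3F)nc2c1`: 10300 nM
Compound 3 `Cc1ccc2c(=O)[nH]c(-c3cccc(F)c3)nc2c1`: 14400 nM

Only two of these results are numbers, and they lie within the usual scatter of each other: compound 2 gives 10300 nM and compound 3 gives 14400 nM. Compound 1 reports only a limit, > 50000 nM.

The next compound to be tested is compound 4 `Cc1ccc2c(=O)[nH]c(-c3cccc(OC(F)(F)F)c3)nc2c1`. It differs from compound 3 by trifluoromethoxy in place of fluoro on an aromatic carbon, meta to a large group (trifluoromethoxy in place of fluoro on an aromatic carbon). No measured step among these compounds shows what this exchange does, so any expectation is loose. A modest move toward a higher number in this assay is expected, meaning somewhat weaker inhibition, though it may not clear the scatter. This expectation rests on two observations. The fluoro compound 3 gives 14400 nM. Compound 1, which carries trifluoromethyl, gives only a limit of the assay, > 50000 nM. The estimated value for compound 4 is 20000 nM, with an expected range from 8000 nM to 50000 nM. This estimate corresponds to an expected step of a 1.4-fold higher number from compound 3 to compound 4 (0.14 log units; within the scatter).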

Compound 4, half-maximal inhibitory concentration: > 50000 nM
Compound 4: a limit, no number; the forecaster's own chance of this, stated with the estimate: 25%; middle value at least 2.5-fold (0.39 log units) away from the limit.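

In this assay, replacing fluoro with trifluoromethoxy on this aromatic carbon, meta to a large group, gives an at least 3.4-fold higher number from compound 3 to compound 4 (0.54 log units; beyond the scatter), the first step among these compounds that can be read for a single change. For the compounds shown here, it shows that the group at this position matters in this cytotoxicity read-out, since the exchange moves the result beyond the scatter, whereas the earlier compounds offered no step of this kind. Only the direction and the minimum size of this step are known, because compound 4 gives a limit of the assay and not a number: the limit of > 50000 nM in this assay, at which 2 of the 4 values shown sit.

The compounds shown leave open whether trifluoromethyl, methoxy, chlorine or an amine at this same place would stay close to compound 3 or also reach the limit, so the exchange cannot yet be traced to any one feature of the entering group. They also leave open how the same exchange would behave at the other positions of this aromatic ring, and whether the effect would be seen on cells other than this single line.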